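Oxazole ketone series: replacing the distal aryl group

A few compounds are considered here, and "the series" means these few. Any claim that something is new, unique, unknown or untested is made for them only; others in the source may bear on it.

Measured so far:
- compound 1 `NC(=O)c1ccc(-c2cnc(C(=O)CCCCCCc3ccccc3)o2)cc1`: 10 nM
- compound 2 `O=C(CCCCCCc1ccccc1)c1ncc(-c2ncccn2)o1`: 5.3 nM

For the measured compounds named here, in an assay (Rattus norvegicus) for inhibition of Fatty-acid amide hydrolase 1 (Homo sapiens) (a lower number here means a stronger inhibitor, a higher number a weaker inhibitor), compound 2 gives the lowest of the two numbers, but the only step recorded, a 1.9-fold lower number from compound 1 to compound 2 (0.28 log units; within the scatter), lies within the scatter, so compounds 1 and 2 are not separable on these data.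

Compound 3 `CSc1cnc(C(=O)CCCCCCc2ccccc2)o1` is not yet measured. Its change from compound 2 is methylsulfanyl in place of pyrimidin-2-yl on an aromatic carbon. Going by the values given here, the one measured step exchanges one six-membered aromatic ring for another at this aromatic carbon and changes little; it does not tell how the series responds when the ring is removed and a methylsulfanyl takes its place. Among the compounds with values here, there is therefore no measured step that bears directly on the change to compound 3, and the expectation rests on the shared core alone. The estimate for compound 3 is a weaker number, a step of a 5.7-fold higher number from compound 2 to compound 3 (0.75 log units; beyond the scatter), with wide uncertainty. Compound 3 is expected at 30 nM, between 7 nM and 130 nM.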

Compound 3, inhibition constant: 25 nM
For compound 3 the middle estimate is 1.2-fold (0.08 log units) above the measured one; the measured number falls inside the stated range.
By their numbers in this assay, from the lowest: compounds 2 and 1 (each within the scatter of the next); then compound 3.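

In this assay, the aromatic carbon next to the ring oxygen tolerates loss of the ring at only modest cost: a 4.7-fold higher number from compound 2 to compound 3 (0.67 log units; beyond the scatter) with methylsulfanyl in place of pyrimidin-2-yl, and a 2.5-fold higher number from compound 1 to compound 3 (0.40 log units; beyond the scatter) with methylsulfanyl in place of 4-carbamoylphenyl. Both steps lie beyond the scatter, so this change separates compounds at a position where the exchange of one six-membered aromatic ring for another did not. Nothing available accounts for the higher number of compound 3.

As far as these compounds go, it remains open whether the step follows the removal of the ring or the presence of sulfur. A methoxy or a plain methyl at this carbon would test that, and a carboxylic acid or an amine would show how far the tolerance extends.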